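Fluoro Substitution on Two Related Bis-indole Oxindole Cores

The source may report more compounds than this note shows. Statements on the series, on what has been measured and on what is new or still open speak of the compounds shown alone.

Compound 1 `COc1cccc2[nH]cc(C3(c4c[nH]c5cccc(OC)c45)C(=O)Nc4ccccc43)c12`: 15300 nM
Compound 2 `COc1ccc2[nH]cc(C3(c4c[nH]c5ccc(OC)cc45)C(=O)Nc4ccccc43)c2c1`: 11200 nM
Compound 3 `COc1cccc2[nH]cc(C3(c4c[nH]c5cccc(OC)c45)C(=O)Nc4ccc(F)cc43)c12`: 7800 nM

The three measured compounds were tested in a functional assay on A549 cells (Homo sapiens) for cytotoxicity, read by MTT assay, with a stated time of 48 h; on this read-out lower numbers stand for stronger inhibition and higher numbers for weaker inhibition. Compound 1 and compound 2 share the same atoms joined differently; the difference between the two cores is not broken down here. In this assay compound 1 gives 15300 nM and compound 2 gives 11200 nM, two values within the usual scatter of each other, so neither can be called the stronger.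

Compound 3 is made from compound 1 by one change, (fluoro in place of hydrogen on an aromatic carbon), and the measured step was a 2.0-fold lower number from compound 1 to compound 3 (0.29 log units; within the scatter). Compound 4 `COc1ccc2[nH]cc(C3(c4c[nH]c5ccc(OC)cc45)C(=O)Nc4ccc(F)cc43)c2c1`, not yet measured, is made from compound 2 by the same change, (fluoro in place of hydrogen on an aromatic carbon). The expectation for compound 4 rests on compound 2, whose value is 11200 nM, and on the step from compound 1 to compound 3, which is expected to repeat as a 1.7-fold lower number from compound 2 to compound 4 (0.24 log units; within the scatter). Compound 4 is therefore estimated at 6500 nM, with a range from 3000 nM to 14000 nM.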

Compound 4, half-maximal inhibitory concentration: 10600 nM
The estimate for compound 4 lay 1.6-fold (0.21 log units) below the measured number; low and high end bracket the measured number.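

In this assay, putting fluoro in place of hydrogen on an aromatic carbon gives a 1.1-fold lower number from compound 2 to compound 4 (0.02 log units; within the scatter). Set beside the earlier use of the same change, the two steps show no real difference: the same change on two cores in this assay, a 2.0-fold lower number (0.29 log units; within the scatter) from compound 1 to compound 3 and a 1.1-fold lower number (0.02 log units; within the scatter) from compound 2 to compound 4, 1.9-fold (0.27 log units) apart, within the scatter of two such steps. So, as far as these two pairs can tell, the change behaves alike on both cores, but this does not show that fluoro alters the cytotoxic effect on either core, since each step is small enough to be ordinary scatter, and two pairs cannot set a rule for the whole series.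

The compounds shown leave open whether a different group on the same aromatic carbon, such as an amine, a nitrile or a carboxylic acid, would give a step large enough to read beyond the scatter. They also leave open whether any such step would carry from one core to the other in the way the fluoro steps appear to do.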